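The compounds below may be only part of what the source reports. "The series", "measured", "known", "first", "only" and "open" are said of these compounds alone.

Of the compounds shown here, two built on the same core have so far been tested in a functional assay on SK-MEL-28 cells (Homo sapiens) for cytotoxicity, read by trypan blue exclusion, with a stated time of 96 h; on this read-out higher numbers stand for weaker inhibition of growth and lower numbers for stronger inhibition of growth. Compound 1 `COc1ccc(NS(=O)(=O)/C=C/c2c(OC)cc(OC)cc2OC)cc1` gives 50 nM in this assay. Compound 2 `COc1cc(OC)c(/C=C/S(=O)(=O)Nc2ccc(OC)c(O)c2)c(OC)c1` carries a hydroxy group on one of its aromatic rings where compound 1 has hydrogen. In this assay compound 2 gives 25 nM. For the measured compounds named here, the only measured step is a 2.0-fold lower number from compound 1 to compound 2 (0.30 log units; within the scatter). Compound 2 therefore holds the lower of the two numbers, but the gap to compound 1 is too small to count as a genuine difference in growth inhibition.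

Compound 3 `COc1cc(OC)c(/C=C/S(=O)(=O)Nc2ccc(OC)c(N)c2)c(OC)c1` has not yet been measured. It differs from compound 2 in one place: amino in place of hydroxy on an aromatic carbon. Going by the values given here, no measured step exchanges hydroxy for amino, so the only guide is a 2.0-fold lower number from compound 1 to compound 2 (0.30 log units; within the scatter), which placed a hydroxy on this same carbon and shifted the number only within the scatter. With one small group replaced by another of similar size, no movement beyond the scatter is anticipated in this assay. Compound 3 is expected to give about 30 nM, most likely between 12 nM and 80 nM. The expected step is a 1.2-fold higher number from compound 2 to compound 3 (0.08 log units; within the scatter).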

Compound 3, concentration for 50% growth inhibition: 8 nM
Beside the measured number, compound 3's estimate is 3.8-fold (0.57 log units) above it; measured number outside the range, below it.
By their numbers in this assay, from the lowest: compound 3; then compounds 2 and 1 (each within the scatter of the next).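

For the compounds shown here, replacing hydroxy with amino on this aromatic carbon in this assay gives a 3.1-fold lower number from compound 2 to compound 3 (0.49 log units; beyond the scatter) and is the first step to lie beyond the scatter. Amino in place of hydrogen on the same carbon gives a 6.3-fold lower number from compound 1 to compound 3 (0.80 log units; beyond the scatter) as a second step beyond the scatter, while hydroxy in place of hydrogen gave only a 2.0-fold lower number from compound 1 to compound 2 (0.30 log units; within the scatter) within it, so at this position the identity of the group matters and not merely the presence of a small group. Hydroxy and amino have the same computed counts of heavy atoms, hydrogen-bond donors and hydrogen-bond acceptors, so these counts do not separate them, and no supporting measurement is available to explain the difference.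

As far as these compounds go, how a methylamino group, an acetylamino group or a fluorine on this carbon would compare with amino in this assay remains open. Also open, from the compounds shown here alone, is whether the step from hydroxy to amino would keep its size with an ethoxy group in place of the methoxy group on the same ring, or in cell lines other than SK-MEL-28.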